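Piperidin-1-yl to morpholin-4-yl on a thiocarbonyl carbon

This account rests on a few compounds, and the source may have more. Where it says the series, first, only, none or still open, it means among the compounds named here.

compound 1 `COc1ccc2occ(CSC(=S)N3CCCCC3)c(=O)c2c1`: 930 nM
compound 2 `CCOC(=O)c1cc(=O)c2cc(CSC(=S)N(C)c3ccccc3)ccc2o1`: 13500 nM

Of the compounds shown here, two have been measured in a functional assay on MDA-MB-435S cells (Homo sapiens) for antiproliferative activity, read by MTT assay, with a stated time of 72 h; on this read-out lower numbers stand for stronger inhibition and higher numbers for weaker inhibition. Compound 1 gives 930 nM, the lowest of the two numbers, while compound 2 gives 13500 nM, a higher number beyond the scatter. Compound 3 `COc1ccc2occ(CSC(=S)N3CCOCC3)c(=O)c2c1` is not yet measured. It differs from compound 1 in one place: morpholin-4-yl in place of piperidin-1-yl on a thiocarbonyl carbon. Among the compounds with values here, no measured pair shows this exchange, so no step is known for it. The step of a 1.6-fold higher number from compound 1 to compound 3 (0.21 log units; within the scatter) is expected to be small, toward a somewhat higher number, likely within the scatter. For compound 3 the expected value is 1500 nM, ranging from 500 nM to 4500 nM.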

Compound 3, half-maximal inhibitory concentration: > 40000 nM
Compound 3: a limit, no number (the forecaster's own chance of this, stated with the estimate: 5%); at least 26-fold (1.42 log units) between middle value and limit.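

In this assay, the group on the thiocarbonyl carbon proves decisive: morpholin-4-yl in place of piperidin-1-yl gives an at least 43-fold higher number from compound 1 to compound 3 (1.63 log units; beyond the scatter). The earlier compounds shown here showed no exchange at this place, and here the core of compound 1 stays the same while the ring gains only its oxygen. Compound 3 stands at a limit of the assay, not at a number: the limit of > 40000 nM in this assay, at which 1 of the 3 values shown sits.

On these data alone, how far compound 3 lies beyond that limit stays open. So does whether pyrrolidin-1-yl, 4-methylpiperazin-1-yl or an open diethylamino group on the same carbon would behave like piperidin-1-yl or like morpholin-4-yl.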